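The compounds below may be only part of what the source reports. "The series", "measured", "known", "first", "only" and "open" are said of these compounds alone.

In an ADME assay on microsomes from liver (Homo sapiens) for metabolic stability (on this read-out lower numbers stand for slow clearance and higher numbers for fast clearance), compound 1 (`O=C(Nc1cccc(Cl)c1)N1CCc2[nH]nc(C(=O)N3CCCCO3)c2C1`) gives 38 mL/min/kg and compound 2 (`CCON(C)C(=O)c1n[nH]c2c1CN(C(=O)Nc1cccc(Cl)c1)CC2`) gives 55 mL/min/kg so the two lie within the scatter of each other, and compound 1 holds no distinct place on these numbers. Compound 3 (`CN(OCCO)C(=O)c1n[nH]c2c1CN(C(=O)Nc1cccc(Cl)c1)CC2`) has not yet been measured. It differs from compound 1 on a carbonyl carbon (a group of 6 heavy atoms (3 carbon, 1 nitrogen, 2 oxygen; no ring) in place of a group of 6 heavy atoms (4 carbon, 1 nitrogen, 1 oxygen; one six-membered non-aromatic ring with 2 hetero atoms), on a carbonyl carbon): the six-membered non-aromatic ring leaves and (2-hydroxyethoxy)(methyl)amino enters. Going by the values given here, the one measured step that bears on this also replaces that ring with a group without a ring (a 1.4-fold higher number from compound 1 to compound 2 (0.16 log units; within the scatter)) and stays within the scatter. Among the compounds with values here, no measured compound carries the hydroxyl, so the data leave that part of the change open. No step beyond the scatter is therefore expected in this assay and the estimated step is small (a 1.1-fold higher number from compound 1 to compound 3 (0.02 log units; within the scatter)). Compound 3 is expected at 40 mL/min/kg (range 20 mL/min/kg to 75 mL/min/kg).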

Compound 3, clearance: 31 mL/min/kg
Beside the measured number, compound 3's estimate is 1.3-fold (0.11 log units) above it; the range from low to high includes it.
By their numbers in this assay, from the lowest: compounds 3, 1 and 2 (each within the scatter of the next).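

In this assay, the open (2-hydroxyethoxy)(methyl)amino group replaces the six-membered ring on the carbonyl carbon with a 1.2-fold lower number from compound 1 to compound 3 (0.09 log units; within the scatter) and thus gives a second group without a ring at this place that stays within the scatter. Going by these compounds alone, the hydroxyl, which the earlier compounds could not address, can now be read on its own: hydroxy in place of hydrogen on the saturated chain comes with a 1.8-fold lower number from compound 2 to compound 3 (0.25 log units; within the scatter) and so brings no step that can be told from repeat measurements. Nothing measured here explains these numbers.

The compounds shown leave open whether an amine or a carboxylic acid at the end of this chain, or a longer chain, would move the clearance beyond the scatter. They also leave open whether a hydroxyl placed on the six-membered ring of compound 1 would behave as it does on the open chain.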